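The source may report more compounds than this note shows. Statements on the series, on what has been measured and on what is new or still open speak of the compounds shown alone.

The measurements here come from an ADME assay on the whole organism for pharmacokinetics, with Rattus norvegicus as the target; a lower number here means that a smaller share of the oral dose reaches the circulation, a higher number that a larger share of the oral dose reaches the circulation. Compound 1 `CC(C)CCN1CCC(C(N)(CCCCB(O)O)C(=O)O)CC1` gives < 5% in this read-out, which is a limit of the assay and not a number. Compound 2 `NC(CCCCB(O)O)(C(=O)O)C1CCN(Cc2ccc(Cl)cc2)CC1` gives < 5%, which is again a limit and not a number. Compound 2 therefore has no exact position, and the whole picture so far is the limit of < 5% in this assay, at which 2 of the 2 values shown sit. Among the compounds with values here, the one measured step is a step that the two limits leave unreadable from compound 1 to compound 2, so it offers no size that can be carried forward.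

Compound 3 `NC(CCCCB(O)O)(C(=O)O)C1CCN(Cc2ccc(Cl)c(Cl)c2)CC1` is compound 2 with one small change, chloro in place of hydrogen on an aromatic carbon, which turns 4-chlorobenzyl into 3,4-dichlorobenzyl. Within the data shown here, nothing measured so far points to a rise or a fall from this change. Compound 1 and compound 2 differ by a larger swap of groups, yet the result for both is the limit of < 5% in this assay, at which 2 of the 2 values shown sit. The expected outcome is therefore no change beyond the usual scatter, and most likely another limit, with an estimated step that the limit leaves unreadable from compound 2 to compound 3. Compound 3 is expected at about 3%, with an estimated range from 1% to 8%.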

Compound 3, oral bioavailability in the Rattus norvegicus assay: > 50%
Compound 3 ended at the assay's limit; the forecaster's own chance of this, stated with the estimate: 85%; middle value at least 47 percentage points from the limit.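

In the Rattus norvegicus assay, the added chloro on the aromatic carbon ortho to the existing chloro group gives a number at least 45 percentage points higher from compound 2 to compound 3 (beyond the scatter), so a change of one heavy atom at this place can move the result a long way, which the two earlier compounds could not show while both sat at the same limit. In the Rattus norvegicus assay, the swap of isobutyl for 3,4-dichlorophenyl gives a number at least 45 percentage points higher from compound 1 to compound 3 (beyond the scatter), whereas the step from compound 1 to compound 2 cannot be read, so among the compounds shown only the 3,4-dichlorobenzyl group stands clear of the lower limit. In a physicochemical assay for lipophilicity, using the shake flask method, in phosphate buffer, measured as octanol-water partition (a lower number here means a more polar compound, a higher number a more lipophilic compound), compound 2 gives 0.3 and compound 3 gives 1.5 as measured values. One possible link to the larger share of the oral dose reaching the circulation is a rise in lipophilicity, seen in the physicochemical assay for the same change: the measured distribution coefficient of compound 2, 0.3, and of compound 3, 1.5, a number 1.20 log units higher (beyond the scatter)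

As far as these compounds go, in the Rattus norvegicus assay compound 3 gives > 50%, which is a limit and not a number, so the true size of the rise remains open. Also open, from the compounds shown here alone, is whether the result depends on chloro itself, or whether a methyl, a methoxy or a trifluoromethyl group at this place would give a similar result.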